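The compounds below may be only part of what the source reports. "The series", "measured", "known", "first", "only" and "open" are said of these compounds alone.

- Compound 1 `COc1cccc(/C=C/C(=O)/C=C/c2ccc(OCc3cn(CCOc4cc(=O)oc5ccccc45)nn3)c(OC)c2)c1`: 77%
- Compound 2 `COc1cc(/C=C/C(=O)/C=C/c2ccco2)ccc1OCc1cn(CCOc2cc(=O)oc3ccccc23)nn1`: 78%

In a functional assay on THP-1 cells (Homo sapiens) for inhibition, read by sulforhodamine B assay, with a stated time of 48 h, tested at 50 uM (a lower number here means less inhibition of growth, a higher number more inhibition of growth at the concentration tested), compound 2 gives 78% and compound 1 gives 77%. These two values lie within the scatter of each other, so compound 2 stands level with compound 1, and the numbers set neither above the other.

The next compound to consider is compound 3 `COc1ccc(/C=C/C(=O)/C=C/c2ccc(OCc3cn(CCOc4cc(=O)oc5ccccc45)nn3)c(OC)c2)cc1`. It carries 4-methoxyphenyl in place of furan-2-yl on a double-bonded chain carbon bound to a double-bonded chain carbon.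

Going by the values given here, only one measured step bears on this change, and it involves the same place in the molecule. That step exchanges 3-methoxyphenyl for furan-2-yl: a number 1 percentage points higher from compound 1 to compound 2 (within the scatter). It is small and stays within the scatter. Among the compounds with values here, no measured compound carries 4-methoxyphenyl, so this single step is a limited guide.

On that evidence, no change beyond the scatter is expected in this assay. The estimated step is a number 1 percentage points lower from compound 2 to compound 3 (within the scatter). For compound 3 the estimated value is 77%, with an expected range from 66% to 87%.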

Compound 3, percent growth inhibition at one concentration: 78%
The estimate for compound 3 lay 1 percentage points below the measured number, and the stated range covers the measured number.
By their numbers in this assay, from the lowest: compounds 1, 2 and 3 (each within the scatter of the next).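

In this assay, the exchange of furan-2-yl, with its five-membered aromatic ring of 5 heavy atoms, for 4-methoxyphenyl, with its six-membered aromatic ring of 8 heavy atoms, gives this result: no change at the digits printed from compound 2 to compound 3 (within the scatter). The earlier step already covered a swap between furan-2-yl and 3-methoxyphenyl, and the new comparison between the two methoxyphenyl groups reads: a number 1 percentage points higher from compound 1 to compound 3 (within the scatter). This position on the double-bonded chain carbon has therefore now taken three different aromatic groups with no difference beyond the scatter, and nothing available offers an explanation for that.

On these data alone, all three groups are aromatic rings, so it remains open whether a basic amine, a carboxylic acid or a longer alkyl chain at this place would leave the growth inhibition where it stands. A reading at one concentration also leaves open whether these three compounds would still stand level at lower concentrations, where a dose series could separate them.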